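A few compounds are considered here, and "the series" means these few. Any claim that something is new, unique, unknown or untested is made for them only; others in the source may bear on it.

The study concerns three measured compounds and one not yet measured, all built on the same core. Compound 1 `C=C1CC[C@H]2C(C)(C)CCC[C@]2(C)[C@H]1C/C=C1/C(=O)OC[C@H]1O` was examined in an ADME assay on RAW264.7 cells (Mus musculus) for cytotoxicity, read by luminescence and CellTiter-Glo, with a stated time of 18 h, tested at 20 uM (on this read-out higher numbers stand for a weaker effect at the one concentration tested and lower numbers for a stronger effect), where compound 1 gives 53.7%. Compound 2 `C=C1CC[C@H]2C(C)(C)CCC[C@]2(C)[C@H]1C[C@@H](O)C1=CCOC1=O` in this assay gives 91.9%, and compound 3 `C=C1CC[C@H]2C(C)(C)CCC[C@]2(C)[C@H]1C/C=C1\CC(OCC)OC1=O` in this assay gives 96.3%. Compound 1 thus has the lowest number of the three; its gap to compound 2, the nearest, and to compound 3, the furthest, both lie beyond the scatter, so compound 1 shows the strongest effect of the three at the one concentration tested.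

Compound 4 `C=C1CC[C@H]2C(C)(C)CCC[C@]2(C)[C@H]1C/C=C1\C(=O)OC[C@H]1O` is the compound still to be measured. Compared with compound 1, (the two compounds have the same atoms and bonds and differ only in configuration as drawn: 1 of 5 stereo elements differ; a double bond is drawn E in compound 1 and Z in compound 4). For the measured compounds named here, no step between two measured compounds differing in only one place is available, so nothing measured can be drawn on for a change of this kind. As the atoms and bonds stay the same and only the drawn configuration of one double bond changes, the account expects compound 4 to remain near compound 1, with a step of a number 6.3 percentage points higher from compound 1 to compound 4 (within the scatter) expected to be modest and most likely within the scatter, though a shift in either direction cannot be ruled out. Compound 4 in this assay is therefore estimated at 60%, within a range from 35% to 90%.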

Compound 4, a percentage reported as activity, at one concentration (the size of the read-out at that concentration, not a potency): 47.5%
Compound 4: middle estimate off by 12.5 percentage points, on the high side, and the stated range covers the measured number.
By their numbers in this assay, from the lowest: compounds 4 and 1 (each within the scatter of the next); then compounds 2 and 3 (each within the scatter of the next).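

For the compounds shown here, the pair gives the first measured step between two compounds that differ in one place, and in this assay that step is a number 6.2 percentage points lower from compound 1 to compound 4 (within the scatter). At this double bond, then, drawing the configuration as Z rather than E does not move the read-out beyond the usual scatter at the one concentration tested, so the two geometries cannot be told apart in this assay. Going by these compounds alone, the comparison is a clean one, with no other structural change to take into account, and the only difference in this pair is this one: the fact that compounds 1 and 4 differ only in the configuration as drawn.

The pair speaks only to the geometry of this one double bond at a single concentration, so it leaves open whether the two compounds would also match in the size of their effect at other concentrations. The compounds shown also leave open what would happen if the hydroxyl group were replaced by an amine or a carboxylic acid, since no step here involves a change of group at all.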